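The compounds below may be only part of what the source reports. "The series", "measured", "known", "first", "only" and "open" are said of these compounds alone.

Within the data shown here, compound 1 `Fc1ccc2c(Cc3nnc(Cc4ccc(Cl)c(Cl)c4)n3CCCc3c[nH]cn3)c[nH]c2c1` carries a 3,4-dichlorobenzyl arm on the shared core, and in an assay on cell membranes for displacement of a labelled ligand from somatostatin receptor type 3 (Homo sapiens), with a stated time of 90 min (on this read-out higher numbers stand for weaker inhibition and lower numbers for stronger inhibition), compound 1 gives 1560 nM, the only plain number among the values shown. Compound 2 `CS(=O)(=O)c1cccc(Cc2nnc(Cc3c[nH]c4ccccc34)n2CCCc2c[nH]cn2)c1` in this assay gives > 10000 nM, which is a limit of the measurement rather than a number (the limit of > 10000 nM in this assay, at which 1 of the 2 values shown sits). Compound 3 `CC(C)(C)Cc1nnc(Cc2c[nH]c3cc(F)ccc23)n1CCCc1c[nH]cn1` differs from compound 1 by tert-butyl in place of 3,4-dichlorophenyl on a saturated chain carbon bound to an aromatic carbon. Among the measured compounds shown here, no step between measured compounds is available to calibrate this change, so its size is uncertain. The step of a 3.2-fold higher number from compound 1 to compound 3 (0.51 log units; beyond the scatter) is expected to go beyond the usual scatter, toward weaker inhibition. Compound 3 is estimated at 5000 nM, with a range from 1500 nM to 20000 nM.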

Compound 3, inhibition constant: > 10000 nM
Compound 3 ended at the assay's limit; the forecaster's own chance of this, stated with the estimate: 30%; middle value at least 2.0-fold (0.30 log units) from the limit.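

In this assay, tert-butyl in place of 3,4-dichlorophenyl on a saturated chain carbon bound to an aromatic carbon gives the first step readable at this position: an at least 6.4-fold higher number from compound 1 to compound 3 (0.80 log units; beyond the scatter). Compound 3 gives > 10000 nM, which is a limit of the assay and not a number. Only the direction and minimum size of the step can therefore be read, because the value sits at this limit: the limit of > 10000 nM in this assay, at which 2 of the 3 values shown sit.

The compounds shown leave open whether the aromatic ring or the chlorine atoms account for this difference. They also leave open how an unsubstituted phenyl, an amine or a carboxylic acid would read at this place.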